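The compounds below may be only part of what the source reports. "The series", "measured", "known", "first", "only" and "open" are said of these compounds alone.

Working notes on the series. Of the compounds shown here, two of the shared core have been measured in an assay on cells for displacement of a labelled ligand from prostaglandin E2 receptor EP4 subtype (Homo sapiens), read by scintillation counting; a lower number here means a stronger inhibitor, a higher number a weaker inhibitor. Compound 1 `COc1ccc(-c2ccc(OCc3cc(C(=O)NS(=O)(=O)c4ccccc4)oc3C)cc2)cc1` gives 5 nM in this assay. Compound 2 `Cc1oc(C(=O)O)cc1COc1ccc(-c2ccc(OC(F)(F)F)cc2)cc1` gives 2400 nM in this assay, the higher of the two numbers; compound 1 sits a long way below it, and the two compounds differ in more than one place, so the gap cannot be attributed to any single change.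

The next compound, compound 3 `CNC(=O)c1ccc(-c2ccc(OCc3cc(C(=O)O)oc3C)cc2)cc1`, keeps the carboxylic acid of compound 2 and alters one substituent: methylcarbamoyl in place of trifluoromethoxy on an aromatic carbon. The group sits on an aromatic carbon of a six-membered aromatic ring of carbon only, para to a large group. Within the data shown here, no measured pair in the set isolates this exchange, and the acid series is represented by compound 2 alone.

Without a comparable step to lean on, the expectation for compound 3 is a step of a 1.6-fold lower number from compound 2 to compound 3 (0.20 log units; within the scatter) from compound 2, small enough to stay near the scatter, with no firm direction. Compound 3 is expected to give 1500 nM in this assay, within a range from 300 nM to 8000 nM.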

Compound 3, inhibition constant: > 10000 nM
Compound 3 was reported as a limit (the forecaster's own chance of this, stated with the estimate: 5%); at least 6.6-fold (0.82 log units) between middle value and limit.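

In this assay, among these compounds, methylcarbamoyl in place of trifluoromethoxy on an aromatic carbon, para to a large group, gives an at least 4.1-fold higher number from compound 2 to compound 3 (0.61 log units; beyond the scatter), and this is the first step that isolates a change at one place. With the carboxylic acid kept, the exchange therefore has a direction at this position: compound 2, with trifluoromethoxy, has the lower number of the pair, and the step lies beyond the scatter. The value of compound 3 is a limit and not a number, so the step gives only a minimum size and its full size stays unknown: the limit of > 10000 nM in this assay, at which 1 of the 3 values shown sits.

The pair cannot separate the hydrogen-bond donor that enters with methylcarbamoyl from the other differences between the two groups, and a tertiary amide such as dimethylcarbamoyl or a nitrile at the same place would be needed to tell these apart. Going by these compounds, it also remains open whether the same exchange would give a step of similar direction and size on a compound carrying the benzenesulfonyl amide of compound 1 instead of the carboxylic acid.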